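This account rests on a few compounds, and the source may have more. Where it says the series, first, only, none or still open, it means among the compounds named here.

For the measured compounds named here, compound 2 `O=C(OCCc1c(-c2ccccc2Cl)c2cc(Cl)ccc2[nH]c1=O)C1CCCC1` has the lower of the two numbers so far in an ADME assay on HepG2 2.2.15 cells (Homo sapiens) for cytotoxicity (on this read-out higher numbers stand for lower toxicity in this test and lower numbers for higher toxicity in this test), where compound 2 gives 46000 nM; its nearest neighbour, compound 1 `CCOCC(=O)OCCc1c(-c2ccccc2Cl)c2cc(Cl)ccc2[nH]c1=O`, gives 130000 nM in this assay. Going by the values given here, the only measured step, a 2.8-fold lower number from compound 1 to compound 2 (0.45 log units; beyond the scatter), is the one that bears on compound 3 `O=C(OCCc1c(-c2ccccc2Cl)c2cc(Cl)ccc2[nH]c1=O)c1ccco1`, which carries furan-2-yl in place of cyclopentyl on a carbonyl carbon. That single step is modest and points in one direction only, so no firm direction follows for this assay; compound 3 is expected to sit near compound 2, with an estimated step of a 1.3-fold higher number from compound 2 to compound 3 (0.12 log units; within the scatter). The estimate for compound 3 is therefore 60000 nM, within a range from 20000 nM to 180000 nM.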

Compound 3, half-maximal cytotoxic concentration: 98000 nM
Compound 3: the middle estimate sits 1.6-fold (0.21 log units) below what was measured, and the stated range covers the measured number.
By their numbers in this assay, from the lowest: compound 2; then compounds 3 and 1 (each within the scatter of the next).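

At this carbonyl carbon, furan-2-yl in place of cyclopentyl gives a 2.1-fold higher number from compound 2 to compound 3 (0.33 log units; beyond the scatter) in this assay, so the read-out is not set by heavy-atom count alone: both groups have the same count, yet an aromatic ring with one hetero atom and a ring of carbon only differ. Furan-2-yl in place of ethoxymethyl gives a 1.3-fold lower number from compound 1 to compound 3 (0.12 log units; within the scatter) and leaves those two groups within the scatter of each other. No supporting evidence accounts for either step.

From the compounds shown here alone, whether the ring's aromaticity or its oxygen matters stays open; phenyl or tetrahydrofuran-2-yl on the same carbonyl carbon would separate the two.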